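The source may report more compounds than this note shows. Statements on the series, on what has been measured and on what is new or still open speak of the compounds shown alone.

Measured in a functional assay on L1210 cells (Mus musculus) for cytotoxicity, with a stated time of 48 h; a lower number here means a stronger inhibitor, a higher number a weaker inhibitor:
compound 1 `CN(C)c1ccc(/C=C2\CCC/C(=C\c3ccccc3[N+](=O)[O-])C2=O)cc1` gives 164000 nM
compound 2 `O=C1/C(=C/c2ccc(Cl)cc2)CCC/C1=C\c1ccccc1[N+](=O)[O-]` gives 9380 nM
compound 3 `O=C1/C(=C/c2ccc(Cl)cc2)CCC/C1=C\c1cccc([N+](=O)[O-])c1` gives 9160 nM

Compound 2 and compound 3 hold the same atoms, joined differently; the difference between the two cores is not broken down here. In this assay compound 2 and compound 3 give numbers within the scatter of each other. From compound 2 to compound 1 the change is dimethylamino in place of chloro on an aromatic carbon; the step was a 17-fold higher number from compound 2 to compound 1 (1.24 log units; beyond the scatter). Compound 4 `CN(C)c1ccc(/C=C2\CCC/C(=C\c3cccc([N+](=O)[O-])c3)C2=O)cc1` is not yet measured. It differs from compound 3 by dimethylamino in place of chloro on an aromatic carbon, the same change at the same place. For compound 4 the expected step is a 16-fold higher number from compound 3 to compound 4 (1.21 log units; beyond the scatter), which rests on the earlier step because a 17-fold higher number from compound 2 to compound 1 (1.24 log units; beyond the scatter). Compound 4 is therefore estimated at 150000 nM, with an expected range from 60000 nM to 400000 nM.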

Compound 4, half-maximal inhibitory concentration: 156000 nM
Compound 4: middle estimate off by 1.0-fold (0.02 log units), on the low side; measured number inside the range.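

In this assay, dimethylamino in place of chloro carries from one core to the other, and the new step, a 17-fold higher number from compound 3 to compound 4 (1.23 log units; beyond the scatter), matches the earlier one: the same change on two cores in this assay, a 17-fold higher number (1.24 log units; beyond the scatter) from compound 2 to compound 1 and a 17-fold higher number (1.23 log units; beyond the scatter) from compound 3 to compound 4, 1.0-fold (0.01 log units) apart, within the scatter of two such steps

With dimethylamino in place, 3-nitrophenyl in place of 2-nitrophenyl gives a 1.1-fold lower number from compound 1 to compound 4 (0.02 log units; within the scatter). This agreement covers only these two cores, which differ only in the nitrophenyl group; it does not show why the step arises or that it holds on any other core.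

Open, as far as these compounds go, is how other groups on the phenyl ring, such as methoxy or a carboxylic acid, compare with chloro and dimethylamino. Also open, from the compounds shown here alone, is whether the step survives with an unsubstituted phenyl in place of the nitrophenyl.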